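The compounds below may be only part of what the source reports. "The series", "measured", "known", "first", "only" and "open" are said of these compounds alone.

Measured in a functional assay on A549 cells (Homo sapiens) for cytotoxicity, read by MTT assay, with a stated time of 72 h; a higher number here means a weaker inhibitor, a lower number a stronger inhibitor:
Compound 1 `O=C(Nc1ccc(Oc2ccnc3[nH]ccc23)cc1)c1ccc(-c2ccc(Cl)cc2)cn1`: > 10000 nM
Compound 2 `COc1ccc(-c2ccnc(C(=O)Nc3ccc(Oc4ccnc5[nH]ccc45)cc3)c2)cc1`: 6970 nM

The entry for compound 1, > 10000 nM, is a limit of the assay and not a number. For the measured compounds named here, compound 2 gives 6970 nM, which makes it the only compound of the two with an actual number, so it offers the one firm reference point.

Compound 3 `O=C(Nc1ccc(Oc2ccnc3[nH]ccc23)cc1)c1cc(-c2ccccc2)ccn1` is the next to be measured. It carries hydrogen in place of methoxy on an aromatic carbon, para to a large group, so 4-methoxyphenyl becomes phenyl: hydrogen in place of methoxy on an aromatic carbon. Going by the values given here, no measured step shows what this change does in this assay, so no shift beyond the scatter is expected, and the estimate stays anchored on compound 2 at 6970 nM. The expected 1.0-fold higher number from compound 2 to compound 3 (0.00 log units; within the scatter) is therefore small. For compound 3 the estimated value is 7000 nM, with an expected range from 2500 nM to 10000 nM.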

Compound 3, half-maximal inhibitory concentration: 2920 nM
The estimate for compound 3 lay 2.4-fold (0.38 log units) above the measured number, and the stated range covers the measured number.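

In this assay, for the compounds shown here, the change from 4-methoxyphenyl to phenyl gives a 2.4-fold lower number from compound 2 to compound 3 (0.38 log units; beyond the scatter), the first measured step in this set. It shows that the number responds to what sits on this aromatic carbon, para to a large group, and that hydrogen there gives the lower number of the pair, though the step is modest and rests on a single pair of compounds. The earlier compounds offered only one number and one limit, with no step between them: the limit of > 10000 nM in this assay, at which 1 of the 3 values shown sits.

The compounds shown leave open how a hydroxyl, an amine or a carboxylic acid would read at this position, so hydrogen is known only against methoxy. They also leave open why the number moves, as only this one read-out is given.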